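The source may hold more compounds than are shown below. What is called first, only, known or untested is meant among the compounds shown, and "the series" means these compounds.

Measured compounds:
compound 1 `Cc1ccc(NC2=CC(=O)c3c(nc4n3[C@H]3OC[C@@H](O)[C@H]3OC4)C2=O)cc1` in a functional assay on MCF7 cells (Homo sapiens) for inhibition, read by sulforhodamine B assay (a lower number here means a stronger inhibitor, a higher number a weaker inhibitor), gives > 4000 nM.
compound 2 `O=C1C=C(Nc2cccc(F)c2)C(=O)c2c1nc1n2[C@H]2OC[C@@H](O)[C@H]2OC1` gives 5500 nM.
compound 3 `CCCN(CCC)C1=CC(=O)c2nc3n(c2C1=O)[C@H]1OC[C@@H](O)[C@H]1OC3` gives > 16000 nM.

The value recorded for compound 1 is a limit of the assay, not a number. That places compound 1 only loosely: its true value could sit anywhere beyond that boundary, so it cannot be ranked against compound 2 with confidence. Compound 3 likewise stands at a limit, as noted under (the limit of > 16000 nM in this assay, at which 1 of the 3 values shown sits).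

Compound 4 `O=C1C(NC2CCCCC2)=CC(=O)c2c1nc1n2[C@H]2OC[C@@H](O)[C@H]2OC1` differs from compound 1 in one place: cyclohexyl in place of 4-methylphenyl on an amine nitrogen. A six-membered aromatic ring of carbon leaves and a six-membered non-aromatic ring of carbon enters, on the amine nitrogen attached to the double-bonded ring carbon.

For the measured compounds named here, one measured step bears on this, though indirectly: an at least 2.9-fold higher number from compound 2 to compound 3 (0.46 log units; beyond the scatter). There the aromatic amine substituent was exchanged for a saturated one, and the number rose by at least a modest amount. Replacing 4-methylphenyl with cyclohexyl is a similar move from aromatic to saturated, so a rise rather than a fall is the more plausible expectation, though compound 1 already sits at a limit, as the limit of > 4000 nM in this assay, at which 1 of the 3 values shown sits, records, which leaves the size of any step uncertain.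

On this basis compound 4 is expected to give 12000 nM, within 4000 nM to 40000 nM, an estimated step that the limit leaves unreadable from compound 1 to compound 4.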

Compound 4, half-maximal inhibitory concentration: > 16000 nM
Compound 4: no number, only a limit; the forecaster's own chance of this, stated with the estimate: 70%; middle value at least 1.3-fold (0.12 log units) away from the limit.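

For the compounds shown here, compound 1 and compound 4 both stand at limits of this assay, so no step between them can be read. The compounds shown leave open whether cyclohexyl in place of 4-methylphenyl on the amine nitrogen changes the inhibition at all, and where the true values of compound 1 and compound 4 lie.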